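The source may hold more compounds than are shown below. What is called first, only, known or untested is meant among the compounds shown, and "the series" means these compounds.

Measured compounds in an ADME assay on 184B5 cells (Homo sapiens) for cytotoxicity, read by MTT assay, with a stated time of 72 h; on this read-out higher numbers stand for weaker inhibition of growth and lower numbers for stronger inhibition of growth:

Compound 1 `COc1ccc(CNc2nc([SeH])nc3ccccc23)cc1`. In this assay compound 1 gives > 100000 nM, which is a limit of the assay and not a number.
Compound 2 `CSc1nc(NCCCc2ccccc2)c2ccccc2n1`. In this assay compound 2 gives > 100000 nM, again a limit of the assay.
Compound 3 `CSc1nc(NCc2ccccc2)c2cccnc2n1`. In this assay compound 3 gives > 100000 nM, also a limit of the assay.

Where compound 2 stands: only a limit is known for it, and every value in the set sits at the same point, (the limit of > 100000 nM in this assay, at which 3 of the 3 values shown sit). Among the measured compounds shown here, no measured value separates compound 2 from compound 1 or compound 3; the three simply share the limit, and no step between any pair of them is given.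

Compound 4 `CSc1nc(NCCCCCO)c2ccccc2n1` has not yet been measured in this assay. It differs from compound 2 as follows: 2-hydroxyethyl in place of phenyl on a saturated chain carbon, three bonds along the chain from a nitrogen on an aromatic ring. For the measured compounds named here, no measured step covers this change, and no evidence is available on what it does to growth inhibition. The expectation is therefore no shift beyond the scatter: compound 4 is expected to remain at the limit, with the expected step from compound 2 to compound 4 being a number no higher from compound 2 to compound 4 (the limit leaves the size open). The estimate for compound 4 in this assay is 100000 nM, with a range from 40000 nM to 250000 nM.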

Compound 4, concentration for total growth inhibition: > 100000 nM
Compound 4 gave a limit, no number (the forecaster's own chance of this, stated with the estimate: 80%); the middle value lies on the limit itself.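

No step can be read between compound 2 and compound 4, as both stand at the same limit of the assay: the limit of > 100000 nM in this assay, at which 4 of the 4 values shown sit.

The compounds shown leave open whether any change to the side chain or the shared core would give a measurable number in this assay.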